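Chloro to bromo on the ethenyl chain

The compounds below may be only part of what the source reports. "The series", "measured", "known", "first", "only" and "open" are said of these compounds alone.

In a functional assay on CCRF-HSB-2 cells (Homo sapiens) for antiproliferative activity (on this read-out lower numbers stand for stronger inhibition and higher numbers for weaker inhibition), compound 1 `Cc1cn([C@@H]2S[C@H](CO)[C@@H](O)[C@@H]2O)c(=O)[nH]c1=O` gives > 100 ug/mL, a limit of the assay and not a number. Compound 2 `O=c1[nH]c(=O)n([C@@H]2S[C@H](CO)[C@@H](O)[C@@H]2O)cc1/C=C/Cl` gives > 100 ug/mL in this assay, again only a limit. The step that the two limits leave unreadable from compound 1 to compound 2 is unreadable for that reason; both values sit at the limit of > 100 ug/mL in this assay, at which 2 of the 2 values shown sit, and compound 2 stands at that limit with no number below it to set against anything.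

Compound 3 `O=c1[nH]c(=O)n([C@@H]2S[C@H](CO)[C@@H](O)[C@@H]2O)cc1/C=C/Br` differs from compound 2 by bromo in place of chloro on a double-bonded chain carbon bound to a double-bonded chain carbon. Among the measured compounds shown here, no measured step bears on this change: the one step between measured compounds, from compound 1 to compound 2, concerns 2-chloroethenyl in place of methyl and is not readable in size. The expectation rests only on where compound 2 stands, at the limit, and on the change being bromo in place of chloro on the same double-bonded chain carbon. For compound 3 no step beyond the scatter is expected, a number no higher from compound 2 to compound 3 (the limit leaves the size open). Compound 3 is estimated at 100 ug/mL, between 40 ug/mL and 300 ug/mL, most likely reported again only as a limit.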

Compound 3, half-maximal inhibitory concentration: > 100 ug/mL
Compound 3: a limit, no number; the forecaster's own chance of this, stated with the estimate: 85%; the middle value sits exactly at the limit.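

No step can be read among compound 1, compound 2 and compound 3 in this assay, as each value is only a limit of the assay: the limit of > 100 ug/mL in this assay, at which 3 of the 3 values shown sit.

The compounds shown leave open how the methyl, 2-chloroethenyl and 2-bromoethenyl groups rank against one another in this assay, with no number available for any of them.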